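The source may hold more compounds than are shown below. What is called first, only, known or untested is meant among the compounds shown, and "the series" means these compounds.

Measured so far in an assay on isolated protein for displacement of a labelled ligand from metabotropic glutamate receptor 5 (Homo sapiens), with a stated time of 60 min, tested at 1 uM; a higher number here means more inhibition at the concentration tested (going by the name of the read-out), a lower number less inhibition:

Compound 1, `Cc1ccc(S(=O)(=O)c2cnc3cc(Cl)ccc3c2N2CCC(C)CC2)cc1F`: 85%
Compound 2, `Cc1ccc(S(=O)(=O)c2cnc3cc(Cl)ccc3c2N2CCC(C)CC2)cc1Cl`: 89%
Compound 3, `Cc1ccc(S(=O)(=O)c2cnc3ccc(F)cc3c2N2CCC(C)CC2)cc1F`: 86%

The three measured compounds all sit in the same region of this assay. Compound 1 and compound 2 share a core and differ in one place, described as chloro in place of fluoro on an aromatic carbon. Across that pair this assay shows a number 4 percentage points higher from compound 1 to compound 2 (within the scatter), so the two numbers cannot be told apart. Compound 3 has a different core; how its core differs from that of compound 1 is not broken down here. Its value in this assay lies close to those of both compound 1 and compound 2, and all three differences fall within the scatter.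

Compound 4, `Cc1ccc(S(=O)(=O)c2cnc3ccc(F)cc3c2N2CCC(C)CC2)cc1Cl`, has not yet been measured. It stands to compound 3 as compound 2 stands to compound 1: the difference is chloro in place of fluoro on an aromatic carbon, the same change as the one between compound 1 and compound 2, occurring here for the second time among these compounds.

For the measured compounds named here, for compound 3 to compound 4 the expected step in this assay is a number 3 percentage points higher from compound 3 to compound 4 (within the scatter), resting on the single earlier example, where the same change gave a number 4 percentage points higher from compound 1 to compound 2 (within the scatter). Because the earlier step of a number 4 percentage points higher from compound 1 to compound 2 (within the scatter) lay within the scatter, compound 4 is expected to land near compound 3. The estimate for compound 4 in this assay is 89%, with a likely range from 80% to 96%.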

Compound 4, a percentage reported as inhibition, at one concentration (the size of the read-out at that concentration, not a potency): 91%
Compound 4: the middle estimate sits 2 percentage points below what was measured; the range from low to high includes it.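

In this assay, the change from 3-fluoro-4-methylphenyl to 3-chloro-4-methylphenyl has now been seen on two cores, and on the second it gives a number 5 percentage points higher from compound 3 to compound 4 (within the scatter). The two steps agree, so within this small set the change carries from one core to the other without any difference that can be told apart: the same change on two cores in this assay, a number 4 percentage points higher (within the scatter) from compound 1 to compound 2 and a number 5 percentage points higher (within the scatter) from compound 3 to compound 4, 1 percentage points apart, within the scatter of two such steps This does not show that chloro and fluoro truly differ on either core, since each step taken alone stays within the scatter, and two pairs cannot establish that the agreement would hold on a further core; a reading at one concentration, moreover, tells only the size of the effect at that concentration for these four compounds.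

The compounds shown carry only fluoro or chloro at this place on the aromatic ring, so it remains open how a nitrile, a methoxy group or a trifluoromethyl group would read there. Going by these compounds, it also remains open whether the two halogens would still be indistinguishable on a core bearing an amine other than the one shared by all four compounds.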